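The compounds below may be only part of what the source reports. "The series", "measured", "known", "first", "only" and "open" are said of these compounds alone.

Of the compounds shown here, two have been tested so far in a functional assay on OVCAR cells (Homo sapiens) for cytotoxicity, read by sulforhodamine B assay, with a stated time of 48 h; on this read-out higher numbers stand for weaker inhibition and lower numbers for stronger inhibition. Compound 1 `CC(=O)N1N=C(c2ccco2)CC1c1ccc(Cl)cc1` gives 31300 nM, and compound 2 `O=CCN1N=C(c2ccc3ccccc3c2)CC1c1ccccc1` gives 21500 nM. These two numbers lie within the usual scatter of repeated measurements, so neither compound can be ranked over the other. They also differ in more than one place, so they do not show the effect of any single structural change.

Compound 3 `O=CCN1N=C(c2ccc3ccccc3c2)CC1c1ccccc1[N+](=O)[O-]` differs from compound 2 in one place: a nitro in place of hydrogen on an aromatic carbon, ortho to a large group, which turns phenyl into 2-nitrophenyl (nitro in place of hydrogen on an aromatic carbon). Going by the values given here, no measured pair of compounds shows what this change does, so the data offer no firm ground for choosing a direction. In this assay, the expectation is therefore no step beyond the scatter. The estimated change, a 1.1-fold lower number from compound 2 to compound 3 (0.05 log units; within the scatter), is accordingly small. Among the compounds with values here, for compound 3, the expected value is 19000 nM, with an estimated range from 7000 nM to 50000 nM, kept wide since only two measurements support it.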

Compound 3, half-maximal inhibitory concentration: 3480 nM
For compound 3 the middle estimate is 5.5-fold (0.74 log units) above the measured one, and the stated range ends above it.
By their numbers in this assay, from the lowest: compound 3; then compounds 2 and 1 (each within the scatter of the next).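

In this assay, going by these compounds alone, the change from phenyl to 2-nitrophenyl gives a 6.2-fold lower number from compound 2 to compound 3 (0.79 log units; beyond the scatter) and is the only single-place step so far that can be read. It shows that this aromatic carbon, ortho to a large group, is not a silent spot: with the rest of compound 2 left as it is, replacing hydrogen with nitro goes with clearly stronger inhibition of these cells. No measurement shown here accounts for this gain, so it stands as an observation without an explanation.

On these data alone, whether the gain belongs to nitro itself or would come with other groups at the same place stays open, and an amine, a chlorine or a methoxy group there would help to tell these apart. As far as these compounds go, it is also open whether nitro at this place would give a similar step on another core, since this single pair is all that speaks for the change.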